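A Methyl Group on the Chain of Compound 1

The source may hold more compounds than are shown below. What is called first, only, known or untested is meant among the compounds shown, and "the series" means these compounds.

Compound 1 `O=C1c2ccccc2C(=O)N1CCOC(=S)N(C(=O)c1cccc([N+](=O)[O-])c1)c1ccc(Cl)cc1` gives 18000 nM in an ADME assay on MT4 cells (Homo sapiens) for cytotoxicity, read by MTT assay; on this read-out lower numbers stand for higher toxicity in this test and higher numbers for lower toxicity in this test. Compound 2 `O=C1c2ccccc2C(=O)N1CCOC(=S)N(C(=O)c1c(Cl)cccc1Cl)c1ccc(Cl)cc1` gives 20000 nM, and compound 3 `Cc1cc(C(=O)N(C(=S)OCCN2C(=O)c3ccccc3C2=O)c2ccc(Cl)cc2)c(C)o1` gives 40000 nM. Compound 1 thus stands level with compound 2 and modestly under compound 3. These three differ only in the group on a carbonyl carbon, and swapping it gave a 1.1-fold higher number from compound 1 to compound 2 (0.05 log units; within the scatter), a 2.2-fold higher number from compound 1 to compound 3 (0.35 log units; beyond the scatter) and a 2.0-fold higher number from compound 2 to compound 3 (0.30 log units; within the scatter).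

Compound 4 `CC(COC(=S)N(C(=O)c1cccc([N+](=O)[O-])c1)c1ccc(Cl)cc1)N1C(=O)c2ccccc2C1=O` keeps that group of compound 1 and changes the chain instead: methyl in place of hydrogen on a saturated chain carbon bound to an amide-type nitrogen in a ring and a saturated chain carbon. Among the compounds with values here, no measured step touches this chain, so the three steps bear on it only indirectly. Even whole-group swaps reached no more than a 2.2-fold higher number from compound 1 to compound 3 (0.35 log units; beyond the scatter), and here a single methyl enters. The expected result in this assay is a 1.2-fold higher number from compound 1 to compound 4 (0.09 log units; within the scatter), which would be no step beyond the scatter. For compound 4 the estimate is 22000 nM, with an expected range from 10000 nM to 45000 nM.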

Compound 4, half-maximal cytotoxic concentration: 77000 nM
For compound 4 the middle estimate is 3.5-fold (0.54 log units) below the measured one, and the stated range ends below it.
By their numbers in this assay, from the lowest: compounds 1, 2, 3 and 4 (each within the scatter of the next, the first and the last beyond it).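

In this assay, methyl in place of hydrogen on a saturated chain carbon bound to an amide-type nitrogen in a ring and a saturated chain carbon gives a 4.3-fold higher number from compound 1 to compound 4 (0.63 log units; beyond the scatter), and a higher number here stands for lower toxicity in this test. Within the data shown here, the earlier steps changed only the group on a carbonyl carbon, so this is the first sign that the chain also bears on the read-out and that one added carbon can take a step beyond the scatter. Nothing available explains this rise.

As far as these compounds go, whether an ethyl group or a longer chain at this carbon would raise the number further remains open. So does whether the same methyl would act alike with 2,6-dichlorophenyl or 2,5-dimethylfuran-3-yl on the carbonyl carbon.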